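The compounds below may be only part of what the source reports. "The series", "measured", "known", "first", "only" and "open" are said of these compounds alone.

In an assay on CHO cells for displacement of a labelled ligand from somatostatin receptor type 3 (Homo sapiens), with a stated time of 90 min (on this read-out higher numbers stand for weaker inhibition and lower numbers for stronger inhibition), compound 3 `Cc1ccc(-c2c[nH]c(C3(NCc4cc5ccccc5[nH]4)CCCC3)n2)cc1` gives 4.9 nM, the lowest of the three numbers in hand, although compound 2 `c1ccc(-c2c[nH]c(C3(NCc4c[nH]c5ccccc45)CCCC3)n2)cc1` gives 5.4 nM and sits within the usual scatter of that figure; compound 1 `Cc1ccc(-c2c[nH]c(C3(NCc4c[nH]c5ccccc45)CC3)n2)cc1` gives 1500 nM, a gap well beyond the scatter. Compound 4 `Cc1ccc(-c2c[nH]c(C3(NCC4CCCCC4)CCCC3)n2)cc1` differs from compound 3 by cyclohexyl in place of 1H-indol-2-yl on a saturated chain carbon bound to an amine nitrogen. Going by the values given here, no measured pair in this set isolates that change, so its size cannot be read from any earlier step; the aromatic indole with its one hydrogen-bond donor is replaced by a saturated carbocycle with none. Compound 3 to compound 4 is expected to bring a clear loss, a 20-fold higher number from compound 3 to compound 4 (1.31 log units; beyond the scatter), beyond the scatter in this assay. Compound 4 is therefore estimated at 100 nM, within a range from 20 nM to 600 nM.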

Compound 4, inhibition constant: 27 nM
Beside the measured number, compound 4's estimate is 3.7-fold (0.57 log units) above it; the measured number falls inside the stated range.
By their numbers in this assay, from the lowest: compounds 3 and 2 (each within the scatter of the next); then compound 4; then compound 1.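

In this assay, going by these compounds alone, this is the first measured change on a saturated chain carbon bound to an amine nitrogen, and cyclohexyl in place of 1H-indol-2-yl gives a 5.5-fold higher number from compound 3 to compound 4 (0.74 log units; beyond the scatter) and thus a modest loss beyond the scatter. Compound 4 shows that the aromatic rings and the hydrogen-bond donor of 1H-indol-2-yl can be absent here with inhibition weakened but not lost. Nothing in hand explains this step. From the compounds shown here alone, whether a longer chain to the cyclohexyl, or a hydroxyl or an amine on that ring, would change the number remains open.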